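Chloro for Methoxy on a Pyridyl Sulfonamide

The source may report more compounds than this note shows. Statements on the series, on what has been measured and on what is new or still open speak of the compounds shown alone.

Compound 1 `CNC(=O)c1cncc(NS(=O)(=O)c2cc(Cl)ccc2OC)c1`: 109 nM
Compound 2 `COc1ccc(S(=O)(=O)Nc2cccnc2)c(OC)c1`: 10300 nM
Compound 3 `COc1ccc(F)cc1S(=O)(=O)Nc1cncc(C(N)=O)c1`: 19 nM

These three compounds were tested in an assay on isolated protein for inhibition of alkaline phosphatase, tissue-nonspecific isozyme (Homo sapiens); a higher number here means a weaker inhibitor, a lower number a stronger inhibitor. Compound 3 gives 19 nM, compound 1 gives 109 nM, and compound 2 gives 10300 nM, the highest of the three numbers; its gap to compound 1 and its gap to compound 3 both lie beyond the scatter. Compound 4 `COc1cc(Cl)ccc1S(=O)(=O)Nc1cccnc1` has not yet been measured. It differs from compound 2 in one place: chloro in place of methoxy on an aromatic carbon. For the measured compounds named here, no measured pair shows this single change on its own, so the size of the step cannot be read from the data. Compound 1 and compound 3 both carry a halogen rather than a second methoxy and have far lower numbers than compound 2, but they also carry an amide group on the other ring, which compound 2 and compound 4 lack, so most of that gap cannot be assigned to the halogen alone. In this assay the expected step is a small one toward a lower number, a 2.9-fold lower number from compound 2 to compound 4 (0.47 log units; beyond the scatter), perhaps only just beyond the scatter. Compound 4 is therefore expected to give 3500 nM in this assay, within a range from 900 nM to 13000 nM.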

Compound 4, half-maximal inhibitory concentration: 4170 nM
Beside the measured number, compound 4's estimate is 1.2-fold (0.08 log units) below it, within the range that was stated.
By their numbers in this assay, from the lowest: compound 3; then compound 1; then compound 4; then compound 2.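

In this assay, the exchange of methoxy for chloro now has a size of its own, as this pair isolates the change on an aromatic carbon that is para to a large group and meta to a methoxy group: there is a 2.5-fold lower number from compound 2 to compound 4 (0.39 log units; beyond the scatter), a modest step. At this position, then, losing the methoxy does not raise the number, and the chloro group brings a small but real shift, with compound 4 still in the micromolar range at 4170 nM. Steps from this pair to compound 1 and compound 3 cannot be read, as those compounds differ from it in more than one place, and nothing available explains the size of the step.

Going by these compounds, it remains open whether the same exchange would give a step of similar size on a core carrying the amide group found in compound 1 and compound 3. On these data alone, it is also open how this position would respond to other groups, such as an amine, a nitrile or a carboxylic acid, and whether any of them would move the number further than chloro does.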